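Shifting the Chlorine from Compound 2 to Compound 3

The source may hold more compounds than are shown below. What is called first, only, known or untested is meant among the compounds shown, and "the series" means these compounds.

Compound 1: `COc1ccc(C2N=C(SCc3ccccc3Cl)NC(C)=C2C(=O)Nc2ccc(F)cc2)cc1OC` — 25.3%
Compound 2: `COc1ccc(C2N=C(SCc3cccc(Cl)c3)NC(C)=C2C(=O)Nc2ccc(F)cc2)cc1OC` — 13.4%

Within the data shown here, in a functional assay on the whole organism (artery, strain albino) with Rattus norvegicus as the target, with a stated time of 180 min, at a dose of 10 mg/kg by the oral route (a higher number here means more inhibition at the dose given (going by the name of the read-out), a lower number less inhibition), compound 2 gives the lowest of the two numbers seen; compound 1 gives a higher value, and the only measured step, a number 11.9 percentage points lower from compound 1 to compound 2 (beyond the scatter), is modest but beyond the scatter. Compound 3, `COc1ccc(C2N=C(SCc3ccc(Cl)cc3)NC(C)=C2C(=O)Nc2ccc(F)cc2)cc1OC`, differs from compound 2 by 4-chlorophenyl in place of 3-chlorophenyl on a saturated chain carbon bound to a sulfur. Among the measured compounds shown here, no measured step bears directly on this change; the single step concerns another position, so no direction can be inferred. Compound 3 is therefore expected to stay near compound 2, with a number 3.6 percentage points higher from compound 2 to compound 3 (within the scatter) within the scatter, at an estimated 17% (range 5% to 35%).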

Compound 3, a percentage reported as inhibition, in the whole organism at one dose (the size of the read-out at that dose, not a potency): 20.1%
For compound 3 the middle estimate is 3.1 percentage points below the measured one; the range from low to high includes it.
By their numbers in this assay, from the lowest: compounds 2, 3 and 1 (each within the scatter of the next, the first and the last beyond it).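

In this assay the 4-chlorophenyl group gives a number 6.7 percentage points higher from compound 2 to compound 3 (within the scatter) and a number 5.2 percentage points lower from compound 1 to compound 3 (within the scatter) so compound 3 cannot be told apart from either of the other two compounds. Among the three chlorophenyl groups on a saturated chain carbon bound to a sulfur, only compound 1 and compound 2 stand apart beyond the scatter, so the three give no clean order. Nothing available explains these numbers. Going by these compounds, it remains open whether the chlorine matters at all, since a plain benzyl group would test this, and whether a 4-methoxybenzyl group would match compound 1 or compound 2.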